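The source may report more compounds than this note shows. Statements on the series, on what has been measured and on what is new or still open speak of the compounds shown alone.

Compound 1 `CCCC(Oc1ccc(-n2cc(Cl)cn2)cc1)c1ccc(C(=O)NCCC(=O)O)cc1` gives 10 mL/min/kg in an ADME assay on microsomes from liver (Homo sapiens) for metabolic stability (a higher number here means faster removal of the compound, a lower number slower removal), and compound 3 `CCCC(Oc1ccc(-n2cc(C)cn2)cc1)c1ccc(C(=O)NCCC(=O)O)cc1` gives 16 mL/min/kg. For the measured compounds named here, the step of a 1.6-fold higher number from compound 1 to compound 3 (0.20 log units; within the scatter) is the only measured step in the set. Compound 2 `CCC(Oc1ccc(-n2cc(C(F)(F)F)cn2)cc1)c1ccc(C(=O)NCCC(=O)O)cc1` returns in this assay only a limit, < 8 mL/min/kg, so its true number is not known. This is the limit of < 8 mL/min/kg in this assay, at which 1 of the 3 values shown sits.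

Compound 4 `O=C(O)CCNC(=O)c1ccc(C(Oc2ccc(-n3cc(C(F)(F)F)cn3)cc2)C2CCC2)cc1` differs from compound 2 by cyclobutyl in place of ethyl on a saturated chain carbon bound to an aromatic carbon and an oxygen on an aromatic ring. Going by the values given here, no measured step covers this change: the step from compound 1 to compound 3 concerns a different part of the shared core and stays within the scatter, so it offers no guide on direction. Compound 4 is therefore estimated near the limit, at 12 mL/min/kg, with a range from 6 mL/min/kg to 25 mL/min/kg. The step of an at least 1.5-fold higher number from compound 2 to compound 4 (0.17 log units; that floor lies within the scatter) is expected as a rough guess only.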

Compound 4, clearance: 26 mL/min/kg
Compound 4: the middle estimate sits 2.2-fold (0.34 log units) below what was measured; the measured number lies above the stated range.
By their numbers in this assay, from the lowest: compounds 1, 3 and 4 (each within the scatter of the next, the first and the last beyond it). At a limit, below all of these: compound 2.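

Cyclobutyl in place of ethyl on a saturated chain carbon bound to an aromatic carbon and an oxygen on an aromatic ring raises the number in this assay, with an at least 3.2-fold higher number from compound 2 to compound 4 (0.51 log units; beyond the scatter). This position therefore gives a step beyond the scatter, which the earlier step, methyl in place of chloro in a different part of the shared core, did not. The value of compound 2 is a limit and not a number: the limit of < 8 mL/min/kg in this assay, at which 1 of the 4 values shown sits.

Still open, from the compounds shown here alone, is whether the rise follows the ring itself or only the added carbon. A butyl chain or a cyclopropyl at this place would separate the two.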